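Swapping the 3-cyanophenyl for propyl on a triazinone scaffold

A few compounds are considered here, and "the series" means these few. Any claim that something is new, unique, unknown or untested is made for them only; others in the source may bear on it.

Measured compounds:
Compound 1 `O=c1nc(SCc2ccccc2)nc(SCc2ccccc2F)[nH]1` — "not determined" (no result reported)
Compound 2 `O=c1nc(SCc2ccccc2)nc(SCc2cccc(F)c2)[nH]1` — 4.18%
Compound 3 `N#Cc1cccc(CSc2nc(SCc3ccccc3)nc(=O)[nH]2)c1` — "not determined" (no result reported)

Three compounds share one core and differ only in the group carried on a saturated chain carbon bound to a sulfur. In an assay for inhibition of Pro-cathepsin H (Homo sapiens), read by fluorescence, tested at 50 uM (a lower number here means less inhibition, a higher number more inhibition at the concentration tested (going by the name of the read-out)), only compound 2 has a number: compound 2 gives 4.18%, a small read-out at the single concentration tested. Compound 1 has no result in this assay. Compound 3 likewise stands without a number: its entry reads "not determined" (no result reported), and one further compound, compound 1, shares that state. On the numbers shown, therefore, compound 3 cannot be placed above or below any other compound; the only anchor available is the weak read-out of compound 2.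

The step from compound 3 to the unmeasured compound 4 `CCCCSc1nc(SCc2ccccc2)nc(=O)[nH]1` is propyl in place of 3-cyanophenyl on a saturated chain carbon bound to a sulfur. Among the compounds with values here, no measured pair shows what such a swap does in this assay, so the size of the step is unknown. Within the data shown here, the only measured value is low, and nothing indicates that the propyl should lift the read-out far from that level; the step is expected to be none beyond the scatter.

Compound 4 is expected to give 5% in this assay, with a range from -8% to 20%.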

Compound 4, a percentage reported as inhibition, at one concentration (the size of the read-out at that concentration, not a potency): -1.81%
Beside the measured number, compound 4's estimate is 6.8 percentage points above it; measured number inside the range.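

In this assay, within the data shown here, the result gives the first measured pair at this position, a saturated chain carbon bound to a sulfur: propyl in place of 3-fluorophenyl gives a number 6 percentage points lower from compound 2 to compound 4 (within the scatter) and so the two compounds cannot be told apart. The aromatic ring of compound 2 and the plain chain of compound 4 therefore both leave the read-out small at the single concentration tested, and in this pair, removing the ring does not produce a change beyond the scatter. Nothing shown bears on why the read-out stays small.

The steps from compound 1 and from compound 3 to compound 4 cannot be read, as neither of those two compounds has a number, so the 3-cyanophenyl group remains unplaced against propyl and against 3-fluorophenyl. The compounds shown also leave open whether a primary amine, a carboxylic acid or a longer chain on this same carbon would give a read-out in this assay that stands clear of the scatter.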